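Cyclopropyl replacements for the propyl amide in the bicyclic series

The source may hold more compounds than are shown below. What is called first, only, known or untested is meant among the compounds shown, and "the series" means these compounds.

Compound 1 `CCCC(=O)N1CC2CC(C1)N2` is the parent of this small set. In an assay on SH-EP1 cells for displacement of a labelled ligand from Neuronal acetylcholine receptor; alpha4/beta2 (Homo sapiens), read by scintillation counting (a higher number here means a weaker inhibitor, a lower number a stronger inhibitor), compound 1 gives 14 nM, the higher of the two numbers recorded so far. Its nearest neighbour is compound 2 `O=C([C@H]1C[C@@H]1F)N1CC2CC(C1)N2`, which in this assay gives 5.4 nM; the step of a 2.6-fold lower number from compound 1 to compound 2 (0.41 log units; beyond the scatter) comes from putting 2-fluorocyclopropyl in place of propyl on the carbonyl carbon.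

Compound 3 `C[C@H]1C[C@H]1C(=O)N1CC2CC(C1)N2` takes a related route: 2-methylcyclopropyl in place of propyl on a carbonyl carbon. Among the measured compounds shown here, only the step from compound 1 to compound 2 bears on this change, and it was modest, so a comparable direction is expected here, tempered by the fact that a methyl rather than a fluorine sits on the three-membered ring and no second such example exists.

Compound 3 is therefore expected to give a number modestly lower than compound 1, a step of a 1.8-fold lower number from compound 1 to compound 3 (0.24 log units; within the scatter), with an estimate of 8 nM and a range from 3 nM to 25 nM in this assay.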

Compound 3, inhibition constant: 7 nM
Compound 3: the middle estimate sits 1.1-fold (0.06 log units) above what was measured; the range from low to high includes it.
By their numbers in this assay, from the lowest: compounds 2, 3 and 1 (each within the scatter of the next, the first and the last beyond it).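

In this assay, the step of a 2.0-fold lower number from compound 1 to compound 3 (0.30 log units; within the scatter) does not separate the 2-methylcyclopropyl amide from the propyl parent, so the clear difference seen with compound 2 is not confirmed for a second ring-bearing amide. The step of a 1.3-fold higher number from compound 2 to compound 3 (0.11 log units; within the scatter) likewise does not separate the methyl-bearing ring from the fluorine-bearing ring, and on this carbonyl carbon the two substituents read as equivalent within the scatter. No measurement is available that would explain these numbers.

Open, as far as these compounds go, is whether the unsubstituted cyclopropyl group, without methyl or fluorine, would fall with these two compounds or with compound 1. Also open, from the compounds shown here alone, are the other stereoisomers of the 2-methylcyclopropyl group and a longer chain such as butyl on the same carbonyl carbon.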